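Swapping methyl for hydrogen on compound 1

This account rests on a few compounds, and the source may have more. Where it says the series, first, only, none or still open, it means among the compounds named here.

compound 1 `Cc1c(C#N)c(NCCO)nc2nc(NCCO)nc(N)c12` gives 20100 nM
compound 2 `N#Cc1cc2c(N)ncnc2nc1Nc1ccc(S(N)(=O)=O)cc1` gives 19300 nM

For the measured compounds named here, in a functional assay on SNU-638 cells (Homo sapiens) for inhibition, read by sulforhodamine B assay, with a stated time of 2 days (a higher number here means a weaker inhibitor of growth, a lower number a stronger inhibitor of growth), compound 1 gives 20100 nM and stands within the scatter of compound 2 at 19300 nM on the only two numbers known so far. Compound 3 `N#Cc1cc2c(N)nc(NCCO)nc2nc1NCCO` differs from compound 1 by hydrogen in place of methyl on an aromatic carbon opposite the ring nitrogen. Going by the values given here, no measured pair of compounds shows what such a change does. In this assay the expected step of a 1.0-fold lower number from compound 1 to compound 3 (0.00 log units; within the scatter) is therefore none beyond the scatter. For compound 3 the estimated value is 20000 nM with an expected range from 8000 nM to 50000 nM in this measurement.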

Compound 3, concentration for 50% growth inhibition: 10900 nM
Compound 3: the middle estimate sits 1.8-fold (0.26 log units) above what was measured; the range from low to high includes it.
By their numbers in this assay, from the lowest: compounds 3, 2 and 1 (each within the scatter of the next).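

Hydrogen in place of methyl on the aromatic carbon opposite the ring nitrogen, ortho to a cyano group, gives a 1.8-fold lower number from compound 1 to compound 3 (0.27 log units; within the scatter) in this assay and is the first measured step at this position. Here the methyl group can give way to hydrogen without a step beyond the scatter. Nothing measured bears on the reason for this result.

On these data alone, whether another group on this carbon, such as ethyl, an amine or a carboxylic acid, would stay within the scatter remains open. So does whether the swap behaves alike when a longer chain replaces a (2-hydroxyethyl)amino group.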